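Replacing butoxy on the carbonyl carbon of compound 2

The compounds below may be only part of what the source reports. "The series", "measured", "known", "first", "only" and "open" are said of these compounds alone.

Values so far in a functional assay on SK-OV-3 cells (Homo sapiens) for antiproliferative activity, read by MTT assay (a higher number here means a weaker inhibitor, a lower number a stronger inhibitor), for this series

- compound 1 `CCCOC(=O)N1CCCc2cc(S(=O)(=O)N3CC(c4ccccc4)NC3=O)ccc21` gives 3920 nM
- compound 2 `CCCCOC(=O)N1CCCc2cc(S(=O)(=O)N3CC(c4ccccc4)NC3=O)ccc21` gives 9570 nM
- compound 3 `O=C(CCl)N1CCCc2cc(S(=O)(=O)N3CC(c4ccccc4)NC3=O)ccc21` is reported as "not determined" (no result reported)

Compound 2 at 9570 nM holds the higher of the two numbers in this assay and compound 1 is its nearest neighbour. The unmeasured compound 4 `O=C(CCl)NC(=O)N1CCCc2cc(S(=O)(=O)N3CC(c4ccccc4)NC3=O)ccc21` carries ((chloromethyl)carbonyl)amino in place of butoxy on a carbonyl carbon. Among the compounds with values here, only one measured step bears on this change, and only loosely. It is a 2.4-fold higher number from compound 1 to compound 2 (0.39 log units; beyond the scatter) and it adds a methyl to the saturated chain. Within the data shown here, no measured compound carries the entering group, and compound 3 gives no number to compare. Compound 1 at 3920 nM has the shorter chain and the lower number, so losing the butoxy chain is expected to lower the number, though this direction rests on a single pair. A larger step than the measured one is expected, with wide uncertainty. The estimated change is a 6.4-fold lower number from compound 2 to compound 4 (0.80 log units; beyond the scatter) on this reasoning. For compound 4 the expected value is 1500 nM with an estimated range from 150 nM to 8000 nM in this reading.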

Compound 4, half-maximal inhibitory concentration: 6140 nM
For compound 4 the middle estimate is 4.1-fold (0.61 log units) below the measured one; the measured number falls inside the stated range.
By their numbers in this assay, from the lowest: compounds 1, 4 and 2 (each within the scatter of the next, the first and the last beyond it).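

In this assay, placing ((chloromethyl)carbonyl)amino on the carbonyl carbon in place of butoxy gives a 1.6-fold lower number from compound 2 to compound 4 (0.19 log units; within the scatter), and placing it there in place of propoxy gives a 1.6-fold higher number from compound 1 to compound 4 (0.19 log units; within the scatter). Compound 4 therefore cannot be separated from either alkoxy compound, although those two stand apart by a 2.4-fold higher number from compound 1 to compound 2 (0.39 log units; beyond the scatter), so this position accepts a group with a chlorine and a hydrogen-bond donor without a step beyond the scatter from either one. No supporting data are available to account for this outcome.

From the compounds shown here alone, it remains open whether the chlorine contributes anything to the value of compound 4, and an acetylamino group or a plain amine on the same carbonyl carbon would separate the chlorine from the rest of the entering group. Going by these compounds, it is also open whether the rise in number seen with the longer alkoxy chain extends to other chains, and ethoxy and pentyloxy on the same carbonyl carbon would test this beyond a single pair.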